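Hydroxy and nitro groups on the aryl ring: compound 4

The source may hold more compounds than are shown below. What is called first, only, known or untested is meant among the compounds shown, and "the series" means these compounds.

Measured in a functional assay on MCF7 cells (Homo sapiens) for antiproliferative activity, read by MTT assay, with stated times of 24 h and 72 h; on this read-out lower numbers stand for stronger inhibition and higher numbers for weaker inhibition:
compound 1 (`COc1cc([C@@H]2[C@H](Oc3ccccc3)C(=O)N2c2cc(OC)c(OC)c(OC)c2)cc(OC)c1OC`) gives 29000 nM
compound 2 (`COc1ccc([C@@H]2[C@H](Oc3ccccc3)C(=O)N2c2cc(OC)c(OC)c(OC)c2)cc1[N+](=O)[O-]`) gives 69000 nM
compound 3 (`COc1cc(N2C(=O)[C@@H](Oc3ccccc3)[C@H]2c2ccc(O)c(O)c2)cc(OC)c1OC`) gives 4500 nM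

Compound 3 has the lowest of the three numbers, and its steps to the other two are both beyond the scatter: the modest 6.4-fold lower number from compound 1 to compound 3 (0.81 log units; beyond the scatter) and the large 15-fold lower number from compound 2 to compound 3 (1.19 log units; beyond the scatter). The next structure, compound 4 (`COc1ccc([C@@H]2[C@H](Oc3ccccc3)C(=O)N2c2cc(OC)c(OC)c(OC)c2)c([N+](=O)[O-])c1O`), changes the same saturated ring carbon of the shared core (a group of 12 heavy atoms (7 carbon, 1 nitrogen, 4 oxygen; one six-membered aromatic ring of carbon only) in place of a group of 8 heavy atoms (6 carbon, 2 oxygen; one six-membered aromatic ring of carbon only), on a saturated ring carbon). The entering group keeps a hydroxy substituent, as in the 3,4-dihydroxyphenyl of compound 3, and carries the nitro and methoxy substituents found in the 4-methoxy-3-nitrophenyl of compound 2.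

Within the data shown here, two measured steps bear most directly on this change. Among the measured compounds shown here, the large 15-fold lower number from compound 2 to compound 3 (1.19 log units; beyond the scatter) marks the range between these two aryl groups, while the modest 2.4-fold higher number from compound 1 to compound 2 (0.38 log units; beyond the scatter) is the only step here that adds a nitro-bearing aryl group. For the measured compounds named here, no measured compound shows a hydroxy and a nitro substituent together. A partial return toward compound 2 is therefore expected, with a modest rise rather than the full span. The expected change is a 4.4-fold higher number from compound 3 to compound 4 (0.65 log units; beyond the scatter) in this assay and lies beyond the scatter. Compound 4 is estimated at 20000 nM (expected range 6000 nM to 60000 nM).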

Compound 4, half-maximal inhibitory concentration: 89000 nM
For compound 4 the middle estimate is 4.5-fold (0.65 log units) below the measured one, outside the stated range (above it).
By their numbers in this assay, from the lowest: compound 3; then compound 1; then compounds 2 and 4 (each within the scatter of the next).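

In this assay the low number of compound 3 does not survive this exchange: the result is a 20-fold higher number from compound 3 to compound 4 (1.30 log units; beyond the scatter) and so a hydroxy substituent on the aryl group at this saturated ring carbon does not by itself bring the low number, at least not alongside nitro and methoxy substituents. Compound 2 and compound 4 cannot be told apart, with a 1.3-fold higher number from compound 2 to compound 4 (0.11 log units; within the scatter) and the hydroxy substituent making no difference that can be read, while a 3.1-fold higher number from compound 1 to compound 4 (0.49 log units; beyond the scatter) places compound 4 on the same side of the 3,4,5-trimethoxyphenyl as a 2.4-fold higher number from compound 1 to compound 2 (0.38 log units; beyond the scatter) does for compound 2, so both nitro-bearing aryl groups shown give higher numbers than compound 1, and no compound shown goes against this. No measurement is available that would explain why the hydroxy substituent fails to lower the number in compound 4.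

Whether compound 3 needs both of its hydroxy substituents stays open, as does how much of the high numbers belongs to the nitro substituent itself, since the aryl groups shown differ in more than one substituent at a time. An aryl group carrying a single hydroxy substituent with no nitro, or an amine or a carboxylic acid in place of the nitro substituent, would separate these questions.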